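Lengthening the Sulfonyl Chain of Compound 1

A few compounds are considered here, and "the series" means these few. Any claim that something is new, unique, unknown or untested is made for them only; others in the source may bear on it.

In a physicochemical assay for acid dissociation, compound 1 `CCCCCCS(=O)(=O)c1ccc(O)c(C(=O)Nc2ccc(Br)cc2)c1` gives 5.2. Compound 2 `CCCCS(=O)(=O)c1ccc(O)c(C(=O)Nc2ccc(Br)cc2)c1` gives 5.2, level with compound 1, and these two share the lowest of the three numbers. For the measured compounds named here, compound 3 `CCCCCCCCS(=O)(=O)c1ccc(O)c(C(=O)Nc2ccc(C(F)(F)F)cc2)c1` gives 6.2, the furthest from compound 1 and beyond the scatter, but no one-place step connects them.

Compound 4 `CCCCCCCCCCS(=O)(=O)c1ccc(O)c(C(=O)Nc2ccc(Br)cc2)c1` extends the chain of compound 1: butyl in place of hydrogen on a saturated chain carbon, six bonds along the chain from a sulfonyl sulfur. Going by the values given here, the one measured step that bears on this change shortens the same chain, and it shows no change at the digits printed from compound 1 to compound 2 (within the scatter). A step beyond the scatter is therefore not expected in this assay. The step expected is a number 0.10 log units higher from compound 1 to compound 4 (within the scatter). Compound 4 is estimated at 5.3, within an expected range of 4.9 to 5.9.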

Compound 4, acid dissociation constant: 5.2
Compound 4: the middle estimate sits 0.10 log units above what was measured; measured number inside the range.
By their numbers in this assay, from the lowest: compounds 1, 2 and 4 (each within the scatter of the next); then compound 3.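

In this assay the lengthening step gives no change at the digits printed from compound 1 to compound 4 (within the scatter) and so matches the earlier shortening step at this chain. The larger difference of hexyl in place of hydrogen, four bonds along the chain from a sulfonyl sulfur, gives no change at the digits printed from compound 2 to compound 4 (within the scatter) as well. Across compounds 1, 2 and 4, which share the bromine-bearing core, the number therefore holds level with chain length, now tested in both directions from compound 1. From the compounds shown here alone, whether a longer chain, or an amine or a carboxylic acid on the chain, would hold level too remains open. No supporting data explain the level numbers.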